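The source may report more compounds than this note shows. Statements on the series, on what has been measured and on what is new or still open speak of the compounds shown alone.

Measured so far:
- compound 1 `COc1ccc([N+](=O)[O-])cc1CSc1nc2cc(NC(=O)NC(C)(C)C)ccc2n1C(C)C`: 62 nM
- compound 2 `CNC(=O)Nc1ccc2c(c1)nc(SCc1cc([N+](=O)[O-])ccc1OC)n2C(C)C`: 3300 nM
- compound 3 `CCCn1c(SCc2cc([N+](=O)[O-])ccc2OC)nc2cc(NC(=O)NC(C)(C)C)cc(C(=O)NC)c21`: 41 nM

Of the compounds shown here, three of one series have been tested in an assay on isolated protein for inhibition of Gonadotropin-releasing hormone receptor (Homo sapiens); a lower number here means a stronger inhibitor, a higher number a weaker inhibitor. Compound 2 gives 3300 nM, while compound 1 gives 62 nM. The two differ in one place, (tert-butyl in place of methyl on an amide-type nitrogen), and that change brings a 53-fold lower number from compound 2 to compound 1 (1.73 log units; beyond the scatter). Compound 3 gives 41 nM in this assay ; its core differs from that of compound 2 in more than one place, and the difference between the two cores is not broken down here. Compound 3 and compound 1 lie within the scatter of each other.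

The compound now in question is compound 4 `CCCn1c(SCc2cc([N+](=O)[O-])ccc2OC)nc2cc(NC(=O)NC(C)(C)C)cc(C(=O)NC(C)(C)C)c21`, which differs from compound 3 by tert-butyl in place of methyl on an amide-type nitrogen. The place is described in the same words as for the step from compound 2 to compound 1, although the change cut one bond further out reads differently for the two pairs, so it is the same kind of change rather than the same change. Given that the earlier step was large, the same kind of change might again move the number, but compound 3 already gives 41 nM, close to compound 1, and no second example of this kind of change is available to show that it carries over. The step from compound 3 to compound 4 is therefore expected to be modest, a 1.2-fold lower number from compound 3 to compound 4 (0.07 log units; within the scatter), and compound 4 is expected to give about 35 nM in this assay , between 8 nM and 150 nM.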

Compound 4, half-maximal inhibitory concentration: 410 nM
Estimate against measurement, compound 4: 12-fold (1.07 log units) below; the measured number lies above the stated range.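

In this assay, tert-butyl in place of methyl on an amide-type nitrogen brings a 10-fold higher number from compound 3 to compound 4 (1.00 log units; beyond the scatter), so the direction of the earlier step did not carry over, and the two results clearly disagree: the same change on two cores in this assay, a 53-fold lower number (1.73 log units; beyond the scatter) from compound 2 to compound 1 and a 10-fold higher number (1.00 log units; beyond the scatter) from compound 3 to compound 4, 530-fold (2.73 log units) apart, beyond the scatter of two such steps

The two steps do not concern the same group, however: one turns methylamino into (tert-butyl)amino, while the other turns methylcarbamoyl into (tert-butyl)carbamoyl, and the two pairs also sit on different cores. These two pairs show that the description of the change alone does not fix the outcome in this series, but they do not show whether the reversal goes with the different group, with the rest of the core, or with both, and one example of each gives no rule for either.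

The compounds shown leave open whether methylamino changed to (tert-butyl)amino on the core of compound 3 would give a step like the earlier one. They also leave open how the number would respond to ethyl or isopropyl on the carbamoyl nitrogen, or to a primary carboxamide or a carboxylic acid in place of the methylcarbamoyl group.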